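The source may hold more compounds than are shown below. What is called first, only, known or untested is meant among the compounds shown, and "the series" means these compounds.

Among the measured compounds shown here, in a functional assay on CCRF-CEM cells (Homo sapiens) for cytotoxicity (on this read-out lower numbers stand for stronger inhibition and higher numbers for weaker inhibition), compound 1, `O=c1ccn([C@@H]2S[C@H](CO)[C@H]2CO)c(=O)[nH]1`, gives 4900 nM, the only actual number among the three values shown. Compound 2, `OC[C@H]1[C@H](n2cnc3c(O)ncnc32)S[C@@H]1CO`, gives > 100000 nM, which is a limit of the assay. Compound 3, `Nc1nc(O)c2ncn([C@@H]3S[C@H](CO)[C@H]3CO)c2n1`, gives > 100000 nM, which is also a limit.

The next compound to consider is compound 4, `O=c1ccn([C@H]2S[C@@H](CO)[C@@H]2CO)c(=O)[nH]1`, which is related to compound 1 as follows: the two compounds have the same atoms and bonds and differ only in configuration as drawn: 3 of 3 stereo elements differ (all stereocentres are inverted: mirror images); a stereocentre at a saturated ring carbon is drawn R in compound 1 and S in compound 4; a stereocentre at a saturated ring carbon is drawn S in compound 1 and R in compound 4; a stereocentre at a saturated ring carbon is drawn R in compound 1 and S in compound 4. No atom or bond changes, so the two are mirror images.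

For the measured compounds named here, the one measured step is a step that the two limits leave unreadable from compound 2 to compound 3. Going by the values given here, it involves a different change and gives no size to carry over, and no measured pair shows what inverting the configuration does. Among the compounds with values here, the only other guide is the limit of > 100000 nM in this assay, at which 2 of the 3 values shown sit.

Compound 1 alone has a number at 4900 nM, so a move toward weaker inhibition in this assay is expected rather than a gain, although a result within the scatter of compound 1 remains possible. The expected change is a 5.1-fold higher number from compound 1 to compound 4 (0.71 log units; beyond the scatter), and this estimate is loose. Compound 4 is expected at 25000 nM, with an estimated range from 4000 nM to 100000 nM.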

Compound 4, half-maximal inhibitory concentration: > 100000 nM
Compound 4: only a limit was reported (the forecaster's own chance of this, stated with the estimate: 45%); middle value at least 4.0-fold (0.60 log units) away from the limit.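

Within this set, the mirror-image pair gives the only step with a readable bound. In this assay the full inversion produces an at least 20-fold higher number from compound 1 to compound 4 (1.30 log units; beyond the scatter), and configuration alone separates the compound with a number from a compound at the limit: the fact that compounds 1 and 4 differ only in the configuration as drawn

Compound 4 gives > 100000 nM, which is a limit of the assay, so the step has a lower bound but no exact size. The result also places compound 4 with compounds 2 and 3, which leaves compound 1 as the only compound with a number: the limit of > 100000 nM in this assay, at which 3 of the 4 values shown sit.

The compounds shown leave open whether inverting one or two of the three stereocentres would have a similar effect, as only the complete mirror image appears here, and the step between compound 2 and compound 3 cannot be read. They also do not show how a fluorine atom or a longer chain on the core of compound 1 would change the measured value of compound 1, which is 4900 nM.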